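The source may report more compounds than this note shows. Statements on the series, on what has been measured and on what is new or still open speak of the compounds shown alone.

Measured so far:
compound 1, `O=C(Nc1ccc(Cl)cc1CN1C(=O)c2ccccc2C1=O)C1CCCCC1`: < 1000 nM
compound 2, `O=C(Nc1ccc(Br)cc1CN1C(=O)c2ccccc2C1=O)c1ccccn1`: < 1000 nM

In an assay on CHO cells for positive allosteric modulation of metabotropic glutamate receptor 5 (Rattus norvegicus), read by FLIPR (on this read-out higher numbers stand for an effect only at larger amounts of compound and lower numbers for an effect already at smaller amounts), compound 1 gives only a limit, < 1000 nM. Compound 2 also gives only a limit in this assay, < 1000 nM. Among the compounds with values here, both values sit at the limit of < 1000 nM in this assay, at which 2 of the 2 values shown sit, so no step between measured compounds is available. Compound 3, `COc1ccccc1C(=O)Nc1ccc(Cl)cc1CN1C(=O)c2ccccc2C1=O`, is not yet measured; it differs from compound 1 by 2-methoxyphenyl in place of cyclohexyl on a carbonyl carbon. Within the data shown here, with no measured step to lean on, no size or direction in this assay can be drawn; a step within the usual scatter, or at most a modest one, is expected. For compound 3 the estimate is 300 nM, with a range from 60 nM to 1500 nM. The expected step is a step that the limit leaves unreadable from compound 1 to compound 3.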

Compound 3, half-maximal effective concentration: < 1000 nM
Compound 3: no number, only a limit (the forecaster's own chance of this, stated with the estimate: 30%); the middle value lies beyond the limit too.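

Compound 3, like compound 1, gives only a limit in this assay, so no step between compound 1 and compound 3 can be read: the limit of < 1000 nM in this assay, at which 3 of the 3 values shown sit.

Still open is how the actual values of the compounds shown compare, including 2-methoxyphenyl against cyclohexyl on the carbonyl carbon.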